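Phenylsulfonyl replaces the alkenyl chain on the amine nitrogen

The compounds below may be only part of what the source reports. "The series", "measured", "known", "first", "only" and "open" are said of these compounds alone.

The three measured compounds share a core and differ at the amine beyond the piperidine. In an assay on CHO cells for displacement of a labelled ligand from 5-hydroxytryptamine receptor 1D (Homo sapiens) (on this read-out lower numbers stand for stronger inhibition and higher numbers for weaker inhibition), compound 2 `CC(C)=CCCN(C)C1CCN(CCCc2c[nH]c3ccc(-n4cnnc4)cc23)CC1` gives 2.6 nM, the highest of the three numbers. Compound 1 `c1ccc(C2CCCCN2C2CCN(CCCc3c[nH]c4ccc(-n5cnnc5)cc34)CC2)cc1` gives 1.9 nM in this assay, within the scatter of compound 2, while compound 3 `OC[C@H](NC1CCN(CCCc2c[nH]c3ccc(-n4ccnc4)cc23)CC1)c1ccccc1` gives 0.7 nM, beyond the scatter of compound 2. Compound 4 `CN(C1CCN(CCCc2c[nH]c3ccc(-n4cnnc4)cc23)CC1)S(=O)(=O)c1ccccc1` carries phenylsulfonyl in place of 4-methylpent-3-en-1-yl on an amine nitrogen, so the amine nitrogen becomes a sulfonamide nitrogen. Among the measured compounds shown here, no measured pair shows this change. Compound 4 is expected to bind more weakly than compound 2, with a step of a 5.8-fold higher number from compound 2 to compound 4 (0.76 log units; beyond the scatter) beyond the scatter, because every measured compound keeps a basic amine at that position and compound 2 gives 2.6 nM. Compound 4 is estimated at 15 nM in this assay, within 3 nM to 80 nM.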

Compound 4, half-maximal inhibitory concentration: 1.5 nM
For compound 4 the middle estimate is 10-fold (1.00 log units) above the measured one, outside the stated range (below it).
By their numbers in this assay, from the lowest: compound 3; then compounds 4, 1 and 2 (each within the scatter of the next).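

In this assay the step is a 1.7-fold lower number from compound 2 to compound 4 (0.24 log units; within the scatter) for phenylsulfonyl in place of 4-methylpent-3-en-1-yl on this amine nitrogen. It is the only step shown at this position, and it shows that the nitrogen can carry a sulfonyl group and an aromatic ring with no change beyond the scatter. Nothing available explains why the number stays within the scatter.

The compounds shown leave open whether the phenyl ring or the sulfonyl group matters here. A benzoyl or methanesulfonyl group on the same nitrogen would separate the two.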